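This account rests on a few compounds, and the source may have more. Where it says the series, first, only, none or still open, it means among the compounds named here.

Among the compounds with values here, compound 2 `CCCCc1coc([C@@H](CC)Nc2c(Nc3cccc(C(=O)N(C)C)c3O)c(=O)c2=O)c1` stands at 34 nM in an assay on CHO cells for displacement of a labelled ligand from C-X-C chemokine receptor type 1 (Homo sapiens) (on this read-out lower numbers stand for stronger inhibition and higher numbers for weaker inhibition), the higher of the two numbers measured so far; the other, compound 1 `CCc1coc([C@@H](CC)Nc2c(Nc3cccc(C(=O)N(C)C)c3O)c(=O)c2=O)c1`, gives 7 nM in this assay. Within the data shown here, the single step measured, a 4.9-fold higher number from compound 1 to compound 2 (0.69 log units; beyond the scatter), came from lengthening the chain on the furan ring. Compound 3 `CC[C@@H](Nc1c(Nc2cccc(C(=O)N(C)C)c2O)c(=O)c1=O)c1cc(C2CCCC2)co1` differs from compound 2 by cyclopentyl in place of butyl on an aromatic carbon. Among the measured compounds shown here, no measured step covers a chain closing into a ring at this position; the one step measured only shows that a larger group here gave a higher number. Since the size of the group barely changes from compound 2 to compound 3, the step of a 1.3-fold higher number from compound 2 to compound 3 (0.12 log units; within the scatter) is expected to be small, with the direction uncertain and a slight rise the more likely. Compound 3 is therefore estimated at 45 nM, within 12 nM to 160 nM.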

Compound 3, inhibition constant: 53 nM
Beside the measured number, compound 3's estimate is 1.2-fold (0.07 log units) below it; low and high end bracket the measured number.
By their numbers in this assay, from the lowest: compound 1; then compounds 2 and 3 (each within the scatter of the next).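

At the aromatic carbon two ring bonds from the ring oxygen, closing the chain into a cyclopentyl ring leaves the number in this assay within the scatter of the butyl compound (a 1.6-fold higher number from compound 2 to compound 3 (0.19 log units; within the scatter)). Cyclopentyl thus stays apart from ethyl (a 7.6-fold higher number from compound 1 to compound 3 (0.88 log units; beyond the scatter)), so of the three groups only ethyl is separated from the others by more than the scatter, and the ring brings no return towards compound 1. Nothing available explains this outcome.

The compounds shown leave open whether a smaller ring such as cyclopropyl, or a branched chain such as isopropyl, would stand with ethyl or with butyl and cyclopentyl. They also leave open how propyl, or a ring carrying oxygen such as tetrahydrofuranyl, would read at this position.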